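A few compounds are considered here, and "the series" means these few. Any claim that something is new, unique, unknown or untested is made for them only; others in the source may bear on it.

Compound 1 (`Cc1ccccc1NNC(=O)c1ccccc1NS(=O)(=O)c1cnc(O)nc1O`) is tested in a functional assay on OVCAR-3 cells (Homo sapiens) for antiproliferative activity, read by MTT assay, with a stated time of 24 h (on this read-out lower numbers stand for stronger inhibition and higher numbers for weaker inhibition), and reads > 20000 nM as a limit of the assay, not a number. Among the measured compounds shown here, compound 2 (`CCCCOc1ccc(C(=O)NNC(=O)c2ccccc2NS(=O)(=O)c2cnc(O)nc2O)cc1`) gives 5010 nM in this assay and so holds the only true number, with no second number to rank it against.

The next compound to be read is compound 3 (`Cc1ccc(C(=O)NNC(=O)c2ccccc2NS(=O)(=O)c2cnc(O)nc2O)cc1`), which carries methyl in place of butoxy on an aromatic carbon of a six-membered aromatic ring of carbon only, para to a large group (methyl in place of butoxy on an aromatic carbon). The same difference can be read as 4-butoxyphenyl to 4-methylphenyl. For the measured compounds named here, no measured pair gives a size for this kind of change, so the expectation rests only on compound 2 at 5010 nM and on the structural change itself. In this assay a modest step toward weaker inhibition is expected, not a gain. The expected size is a 2.2-fold higher number from compound 2 to compound 3 (0.34 log units; beyond the scatter) and remains a rough estimate. For compound 3 the estimated value is 11000 nM with an expected range from 3500 nM to 20000 nM in this assay.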

Compound 3, half-maximal inhibitory concentration: 12900 nM
Beside the measured number, compound 3's estimate is 1.2-fold (0.07 log units) below it, within the range that was stated.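

In this assay, among the compounds shown here, methyl in place of butoxy on an aromatic carbon, para to a large group, gives a 2.6-fold higher number from compound 2 to compound 3 (0.41 log units; beyond the scatter), which is the first measured size for a change at this position, and within this pair the butoxy group goes with the stronger inhibition. Compound 3 also gives the series a second true number, so compound 2 can now be ranked against a value and not only against a limit. The other step is an at least 1.5-fold lower number from compound 1 to compound 3 (0.19 log units; that floor lies within the scatter); the reading of compound 1 is a limit of the assay and not a number, and the floor of this step lies within the scatter, so it fixes no order between the two compounds: the limit of > 20000 nM in this assay, at which 1 of the 3 values shown sits.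

The change from butoxy to methyl removes the chain and the ether oxygen together, and the two remain unseparated here; methoxy or pentyl at the same position would tell them apart. Butoxy and methyl give only two points at this position, so it remains open whether a longer chain such as hexyloxy would continue the difference or whether a polar group such as an amine or a carboxylic acid would be tolerated.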